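A few compounds are considered here, and "the series" means these few. Any claim that something is new, unique, unknown or untested is made for them only; others in the source may bear on it.

Compound 1 `Cc1cc(=O)n(-c2ccccc2OC(F)(F)F)nc1C(=O)Nc1ccc(Oc2ncnc3[nH]ccc23)c(F)c1`: 11700 nM. Compound 2 `Cc1cc(=O)n(-c2ccccc2OC(F)(F)F)nc1C(=O)Nc1ccc(Oc2ncnc3c2ccn3C)cc1`: 27000 nM. Compound 3 `Cc1cc(=O)n(-c2ccccc2C(F)(F)F)nc1C(=O)Nc1ccc(Oc2ncnc3c2ccn3C)cc1`: 7840 nM.

All three were measured in a functional assay on MCF7 cells (Homo sapiens) for cytotoxicity, read by MTT assay, with a stated time of 72 h; on this read-out higher numbers stand for weaker inhibition and lower numbers for stronger inhibition. Compound 2 stands highest of the three numbers; both compound 1 and compound 3 give lower numbers, each beyond the scatter of compound 2, while compound 1 and compound 3 lie within the scatter of each other. Among the measured compounds shown here, the single one-place step among them, a 3.4-fold lower number from compound 2 to compound 3 (0.54 log units; beyond the scatter), concerns the group on the phenyl that sits on the pyridazinone and lowers the number modestly.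

Compound 4 `Cc1cc(=O)n(-c2ccccc2OC(F)(F)F)nc1C(=O)Nc1ccc(Oc2ncnc3c2ccn3C)c(F)c1` differs from compound 2 by fluoro in place of hydrogen on an aromatic carbon. For the measured compounds named here, no measured step covers this particular change: the step from compound 2 to compound 3 alters a different group, and compound 1, which also carries a fluoro group, differs from compound 2 in more than one respect, so only their two values can be set side by side. Compound 1 gives 11700 nM. Compound 2 gives 27000 nM. That comparison suggests, at most, a small to modest move toward a lower number for a fluoro addition, but it cannot be attributed to the fluoro alone.

Compound 4 is therefore expected to give about 16000 nM in this assay, with a likely range of 6000 nM to 40000 nM. The expected step of a 1.7-fold lower number from compound 2 to compound 4 (0.23 log units; within the scatter) is estimated to be small, toward a lower number, and close to the scatter.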

Compound 4, half-maximal inhibitory concentration: > 60000 nM
Compound 4 was reported as a limit; the forecaster's own chance of this, stated with the estimate: 5%; middle value at least 3.7-fold (0.57 log units) from the limit.
By their numbers in this assay, from the lowest: compounds 3 and 1 (each within the scatter of the next); then compound 2. At a limit, above all of these: compound 4.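

Compound 4 is reported in this assay only as a limit, not as a number: the limit of > 60000 nM in this assay, at which 1 of the 4 values shown sits. The earlier compounds shown here held no single-place step at this aromatic carbon, and an at least 2.2-fold higher number from compound 2 to compound 4 (0.34 log units; beyond the scatter) now shows that fluoro in place of hydrogen, ortho to a large group and meta to a large group, goes with weaker inhibition on this read-out, though the limit leaves the full size of the step unknown. Among the compounds shown here, with the fluoro kept in both compounds, an at least 5.1-fold higher number from compound 1 to compound 4 (0.70 log units; beyond the scatter) gives the first single-place reading of methyl in place of hydrogen on an aromatic nitrogen, and this change also goes toward weaker inhibition.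

The compounds shown leave open whether fluoro has the same effect when trifluoromethyl stands in place of trifluoromethoxy, as it does in compound 3, and how far each step truly reaches. They also leave open how chloro or methoxy would read at this aromatic carbon, and how an ethyl group or a longer chain would read on the aromatic nitrogen.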